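This account rests on a few compounds, and the source may have more. Where it says the series, first, only, none or still open, it means among the compounds named here.

Compound 1, `Oc1ccc2nc(-c3ccccc3)cc(O)c2c1`, gives 7.75 ug/mL in a functional assay on HCT-8 cells (Homo sapiens) for cytotoxicity; a higher number here means that more compound is needed for the effect, a lower number that less compound is needed. Compound 2, `Oc1cc(-c2ccccc2)nc2c(F)cccc12`, gives 0.04 ug/mL in this assay. For compound 3, `CCCCOc1cc(-c2ccccc2)nc2ccccc12`, the reported value > 10 ug/mL is a limit of the assay rather than a number.

Compound 3 therefore stands at the limit, the only one of the three to do so, as the limit of > 10 ug/mL in this assay, at which 1 of the 3 values shown sits, records, while compound 1 and compound 2 both return measurable numbers. The step followed here leads from compound 3 to compound 4, `c1ccc(COc2cc(-c3ccccc3)nc3ccccc23)cc1`, which has not yet been measured in this assay. The change is phenyl in place of propyl on a saturated chain carbon bound to an oxygen on an aromatic ring. Within the data shown here, no step between two measured compounds is available to calibrate this change, so the expectation rests on where compound 3 stands alone. Compound 3 sits at a limit, so the step that the limit leaves unreadable from compound 3 to compound 4 is expected to be small or not beyond the scatter, with a real chance that compound 4 also returns only a limit. Compound 4 is estimated at 15 ug/mL, within a range from 3 ug/mL to 60 ug/mL.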

Compound 4, half-maximal effective concentration: > 10 ug/mL
Compound 4: a limit, no number; the forecaster's own chance of this, stated with the estimate: 60%; the middle value is on the limit's open side.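

In this assay compound 3 gives > 10 ug/mL, a limit and not a number. Among these compounds, compound 4 gives > 10 ug/mL, also a limit, so no step between compound 3 and compound 4 can be read. The compounds shown leave open whether phenyl in place of propyl changes this read-out at all.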